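Allyl to phenyl on the ring nitrogen: paw edema notes

A few compounds are considered here, and "the series" means these few. Any claim that something is new, unique, unknown or untested is made for them only; others in the source may bear on it.

Measured so far in a functional assay on the whole organism (strain albino) for inhibition, with Rattus norvegicus as the target, read by paw edema, with a stated time of 5 h, at a dose of 0.28 mmol/kg by the oral route; on this read-out higher numbers stand for more inhibition at the one dose given (going by the name of the read-out) and lower numbers for less inhibition:
compound 1, `COc1ccc(-c2nnc(SCC(=O)c3ccccc3)n2-c2ccccc2)cc1OC`, 59%
compound 2, `C=CCn1c(SCC(=O)c2ccccc2)nnc1-c1ccc(OC)c(OC)c1`, 62%
compound 3, `C=CCn1c(SC/C(=N/O)c2ccccc2)nnc1-c1cc(OC)c(OC)c(OC)c1`, 77%

Compound 4, `COc1cc(-c2nnc(SC/C(=N/O)c3ccccc3)n2-c2ccccc2)cc(OC)c1OC`, is not yet measured. Compound 1 and compound 2 differ in one place, (phenyl in place of allyl on an aromatic nitrogen), and that change gave a number 3 percentage points lower from compound 2 to compound 1 (within the scatter). The difference between the core of compound 3 and the core of compound 2 is not broken down here; compound 3 stands highest of the three, beyond the scatter from both of the others. Compound 4 relates to compound 3 by phenyl in place of allyl on an aromatic nitrogen, the same change as in the measured pair, at the same place. On that one step, compound 4 is expected to sit near compound 3 in this assay, with a number 3 percentage points lower from compound 3 to compound 4 (within the scatter). The estimate for compound 4 is 74%, between 62% and 86%, resting on a single measured pair and so held wide.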

Compound 4, a percentage reported as inhibition, in the whole organism at one dose (the size of the read-out at that dose, not a potency): 68%
For compound 4 the middle estimate is 6 percentage points above the measured one; measured number inside the range.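

Phenyl in place of allyl on an aromatic nitrogen has now been read on two cores in this assay, and the new pair gives a number 9 percentage points lower from compound 3 to compound 4 (within the scatter). The two steps do not separate: the same change on two cores in this assay, a number 3 percentage points lower (within the scatter) from compound 2 to compound 1 and a number 9 percentage points lower (within the scatter) from compound 3 to compound 4, 6 percentage points apart, within the scatter of two such steps. The change therefore carries from one core to the other without a step beyond the scatter, but a single pair on each core does not show that the step is equal on both, or that it would hold on a further core.

The compounds shown leave open other groups on that aromatic nitrogen, such as a methyl, a benzyl or a longer chain. The two cores also differ in more than one place, so no single difference between them can be read here.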